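A Methyl Group Added to the Phenyl of Compound 3

The source may hold more compounds than are shown below. What is called first, only, known or untested is meant among the compounds shown, and "the series" means these compounds.

Of the compounds shown here, three built on one shared core have been measured in a functional assay on WM 266-4 cells (Homo sapiens) for inhibition, read by sulforhodamine B assay, with a stated time of 5 days; a higher number here means a weaker inhibitor of growth, a lower number a stronger inhibitor of growth. Compound 1 `CC(C)(C)c1cc(NC(=O)Nc2ccc(Oc3ccnc4[nH]c(=O)[nH]c34)cc2)n(-c2ccccc2)n1` gives 3200 nM. Compound 2 `Cn1c(=O)[nH]c2nccc(Oc3ccc(NC(=O)Nc4cc(C(C)(C)C)nn4-c4ccccc4)c4ccccc34)c21` gives 1200 nM. Compound 3 `CC(C)(C)c1cc(NC(=O)Nc2ccc(Oc3ccnc4[nH]c(=O)[nH]c34)cc2F)n(-c2ccccc2)n1` gives 660 nM, the lowest of the three numbers; its gap to compound 2 lies within the scatter, whereas the step of a 4.8-fold lower number from compound 1 to compound 3 (0.69 log units; beyond the scatter) lies beyond it.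

Compound 4 `Cc1ccc(-n2nc(C(C)(C)C)cc2NC(=O)Nc2ccc(Oc3ccnc4[nH]c(=O)[nH]c34)cc2F)cc1` differs from compound 3 by methyl in place of hydrogen on an aromatic carbon; read one bond further out, the change is phenyl to 4-methylphenyl. Within the data shown here, no measured step touches this position: the only step among the measured compounds, the fluoro for hydrogen change that sets compound 3 apart from compound 1, sits on a different ring and says nothing about a methyl on the phenyl. Among the measured compounds shown here, with no comparable step in hand, the estimated step of a 1.0-fold lower number from compound 3 to compound 4 (0.01 log units; within the scatter) is expected to stay within the scatter, in no particular direction. Compound 4 is therefore expected to give about 650 nM in this assay, within a range from 250 nM to 1700 nM.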

Compound 4, concentration for 50% growth inhibition: 790 nM
Beside the measured number, compound 4's estimate is 1.2-fold (0.08 log units) below it; low and high end bracket the measured number.
By their numbers in this assay, from the lowest: compounds 3, 4 and 2 (each within the scatter of the next); then compound 1.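

In this assay, among these compounds, the step of a 1.2-fold higher number from compound 3 to compound 4 (0.08 log units; within the scatter) is the first reading of any change on the phenyl, and it lies within the scatter, so no difference can be read between the two compounds. A methyl on this aromatic carbon, para to a large group, is thus compatible with growth inhibition at the level of compound 3. This sets the change apart from the step of a 4.8-fold lower number from compound 1 to compound 3 (0.69 log units; beyond the scatter) on the other ring, which lies beyond the scatter.

The compounds shown leave open whether this holds only for methyl, since an amine, a carboxylic acid or a longer chain such as butyl on the same carbon could read differently. They also leave open whether the methyl would read the same without the fluoro of compound 3. Nothing available explains the result for compound 4.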